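A few compounds are considered here, and "the series" means these few. Any claim that something is new, unique, unknown or untested is made for them only; others in the source may bear on it.

Measured compounds:
- compound 1 `O=C(Nc1ccc(Oc2ccnc3[nH]ccc23)c(F)c1)c1cc2cccnc2n(-c2ccc(Br)cc2F)c1=O`: "not determined" (no result reported) in a functional assay on U-87MG ATCC cells for antiproliferative activity against U-87 MG (Homo sapiens), read by MTT assay, with a stated time of 72 h; on this read-out higher numbers stand for weaker inhibition and lower numbers for stronger inhibition
- compound 2 `Cn1ccc2c(Oc3ccc(NC(=O)c4cc5cccnc5n(-c5ccc(Cl)cc5)c4=O)cc3F)ccnc21`: "not determined" (no result reported) in this assay
- compound 3 `Cn1ccc2c(Oc3ccc(NC(=O)c4cc5cccnc5n(-c5ccc(Br)cc5)c4=O)cc3F)ccnc21`: 2580 nM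

Compound 3 is the only member of this set with a number in this assay; compounds 1 and 2 carry no result there, so compound 3 stands alone on the numbers shown, and no comparison with a neighbour is possible.

Compound 4 `Cn1ccc2c(Oc3ccc(NC(=O)c4cc5cccnc5n(-c5ccc(Br)cc5F)c4=O)cc3F)ccnc21` differs from compound 3 in one place: fluoro in place of hydrogen on an aromatic carbon, ortho to a large group and meta to a bromo group. Going by the values given here, no measured pair shows what this change does here. The step is expected to stay within the usual scatter, as a 1.2-fold lower number from compound 3 to compound 4 (0.07 log units; within the scatter). Compound 4 is therefore estimated at 2200 nM, with a range from 700 nM to 7000 nM.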

Compound 4, half-maximal inhibitory concentration: 6470 nM
Compound 4: middle estimate off by 2.9-fold (0.47 log units), on the low side; the range from low to high includes it.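

In this assay, this position proves sensitive to a single added atom: going from 4-bromophenyl to 4-bromo-2-fluorophenyl gives a 2.5-fold higher number from compound 3 to compound 4 (0.40 log units; beyond the scatter), a modest weakening of inhibition beyond the usual scatter. Going by these compounds alone, it is the first measured step in this set, and it concerns fluoro in place of hydrogen only. No available evidence explains the shift.

As far as these compounds go, whether a methoxy group or an amine at this position would shift the value in the same direction remains open. So does whether the fluoro step would carry over to a chloro group in place of the bromo group.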